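The compounds below may be only part of what the source reports. "The series", "measured", "known", "first", "only" and "open" are said of these compounds alone.

In a functional assay on MKN-45 cells (Homo sapiens) for inhibition, with a stated time of 72 h (on this read-out lower numbers stand for stronger inhibition and higher numbers for weaker inhibition), three compounds share a core and differ only in the group on an aromatic nitrogen. Compound 1 `CCn1ccc2cc(C(=O)c3cc(OC)c(OC)c(OC)c3)ccc21` gives 31 nM, compound 2 `CCCn1ccc2cc(C(=O)c3cc(OC)c(OC)c(OC)c3)ccc21` gives 680 nM, and compound 3 `COc1cc(C(=O)c2ccc3c(ccn3C(C)C)c2)cc(OC)c1OC` gives 470 nM. Compound 3 therefore stands well above compound 1 on this read-out, and a 1.4-fold lower number from compound 2 to compound 3 (0.16 log units; within the scatter) places it level with compound 2.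

The next change leads to compound 4 `COc1cc(C(=O)c2ccc3c(ccn3CC(=O)O)c2)cc(OC)c1OC`, with carboxymethyl in place of isopropyl on an aromatic nitrogen. Within the data shown here, none of the measured compounds carries carboxymethyl, so no measured step tests this change directly. The closest guides are the two steps that extended the group on the nitrogen of compound 1, a 22-fold higher number from compound 1 to compound 2 (1.34 log units; beyond the scatter) and a 15-fold higher number from compound 1 to compound 3 (1.18 log units; beyond the scatter). Both were large, and carboxymethyl is a bigger group than isopropyl by the count of heavy atoms. A further rise in this assay is therefore expected, probably moderate to large, although the uncertainty is wide because this is a new type of group. For compound 4 the estimated value is 3000 nM, with an expected range from 600 nM to 15000 nM. This estimate means an expected step of a 6.4-fold higher number from compound 3 to compound 4 (0.81 log units; beyond the scatter).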

Compound 4, half-maximal inhibitory concentration: 396 nM
For compound 4 the middle estimate is 7.6-fold (0.88 log units) above the measured one; the whole stated range lies above it.
By their numbers in this assay, from the lowest: compound 1; then compounds 4, 3 and 2 (each within the scatter of the next).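

In this assay the change from isopropyl to carboxymethyl on the aromatic nitrogen leaves the number level (a 1.2-fold lower number from compound 3 to compound 4 (0.07 log units; within the scatter)), and compound 4 also sits level with the propyl-bearing compound (a 1.7-fold lower number from compound 2 to compound 4 (0.23 log units; within the scatter)). The earlier compounds shown here carried only carbon and hydrogen in this group, whereas carboxymethyl brings two oxygen atoms, a hydrogen-bond donor and a hydrogen-bond acceptor, yet it gives the same level as propyl and isopropyl. Among these four compounds, the ethyl-bearing compound 1 alone stands apart from the other three, as the large gap to the acid shows (a 13-fold higher number from compound 1 to compound 4 (1.11 log units; beyond the scatter)), and no measurement offered here explains why three such different groups end up level.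

The compounds shown leave open whether anything smaller than ethyl, such as a methyl group or a bare hydrogen on this nitrogen, would match or pass compound 1, which would show how narrow the preference at this position is. They also leave open how a methyl ester, a primary amide or an aminoethyl group at the same place would compare with the carboxymethyl of compound 4.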